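This account rests on a few compounds, and the source may have more. Where it says the series, first, only, none or still open, it means among the compounds named here.

Series around one shared core, varied only in the acyl group on the carbonyl carbon. Compound 1 `Cc1ccsc1C(=O)OC(CCN(C)C)c1ccc(Cl)cc1` gives 2510 nM in an assay on NIH3T3 cells with Urotensin-2 receptor (Homo sapiens) as the target; on this read-out lower numbers stand for an effect already at smaller amounts and higher numbers for an effect only at larger amounts of compound. Compound 2 `Cc1c(Cl)cccc1C(=O)OC(CCN(C)C)c1ccc(Cl)cc1` gives 1120 nM in this assay, and compound 3 `Cc1ccc(C)c(C(=O)OC(CCN(C)C)c2ccc(Cl)cc2)c1` gives 1860 nM. Compound 3 sits second highest of the three numbers: the nearest is compound 1, with a 1.3-fold lower number from compound 1 to compound 3 (0.13 log units; within the scatter), the furthest compound 2, with a 1.7-fold higher number from compound 2 to compound 3 (0.22 log units; within the scatter); only a 2.2-fold lower number from compound 1 to compound 2 (0.35 log units; beyond the scatter) reaches beyond the scatter. Compound 4 `CN(C)CCC(OC(=O)NCc1ccccc1)c1ccc(Cl)cc1` carries benzylamino in place of 2,5-dimethylphenyl on a carbonyl carbon. For the measured compounds named here, no measured step covers a change of this kind; the three measured steps exchange one aromatic ring for another and stay small. The step from compound 3 to compound 4 is therefore expected as a 1.7-fold higher number from compound 3 to compound 4 (0.24 log units; within the scatter), leaning towards a higher number with wide uncertainty. Compound 4 is expected at 3200 nM, within 900 nM to 12000 nM.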

Compound 4, half-maximal effective concentration: 2140 nM
Beside the measured number, compound 4's estimate is 1.5-fold (0.17 log units) above it; the measured number falls inside the stated range.
By their numbers in this assay, from the lowest: compounds 2, 3, 4 and 1 (each within the scatter of the next, the first and the last beyond it).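

In this assay, benzylamino on a carbonyl carbon stays level with all three aromatic acyl groups (a 1.2-fold higher number from compound 3 to compound 4 (0.06 log units; within the scatter); a 1.9-fold higher number from compound 2 to compound 4 (0.28 log units; within the scatter); a 1.2-fold lower number from compound 1 to compound 4 (0.07 log units; within the scatter)). This position therefore accepts a nitrogen-linked benzyl group with a hydrogen-bond donor, not only a ring bonded directly to the carbonyl carbon, with no step beyond the scatter. No supporting data explain this level behaviour.

Still open, on these data alone, is whether a longer chain in place of benzylamino, or a carboxylic acid on its phenyl ring, would hold this level.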